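The source may report more compounds than this note shows. Statements on the series, on what has been measured and on what is new or still open speak of the compounds shown alone.

Working notes on the series. In a functional assay on NCI-H460 cells (Homo sapiens) for inhibition, read by MTT assay, with a stated time of 24 h, tested at 10 ug/mL (on this read-out lower numbers stand for less inhibition of growth and higher numbers for more inhibition of growth at the one concentration tested), compound 1 (`O=C(CCCCC(S)CCS)NO`) gives 17.7% of growth inhibition, compound 2 (`O=C(CCCCC(S)CCS)Nc1ccccc1Cl`) gives 18.2% on the same scale, and compound 3 (`O=C(CCCCC(S)CCS)Nc1ccc(F)cc1`) gives 18.1% on it too. Compound 3 therefore stands within the scatter of both other compounds, and the three numbers cannot be told apart. Compound 4 (`O=C(CCCCC(S)CCS)Nc1ccc([N+](=O)[O-])cc1`) differs from compound 3 by a single change (nitro in place of fluoro on an aromatic carbon): nitro in place of fluoro on an aromatic carbon, para to a large group. For the measured compounds named here, no measured step between compounds that differ in one place is available to size this change. The basis is therefore thin: compound 3 at 18.1% is the only direct anchor. The estimated a number 1.9 percentage points higher from compound 3 to compound 4 (within the scatter) is small, and no step beyond the scatter is expected in this assay for this swap. For compound 4 the estimate is 20% with an expected range of 10% to 35% on present data.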

Compound 4, percent growth inhibition at one concentration: 13.4%
The estimate for compound 4 lay 6.6 percentage points above the measured number; low and high end bracket the measured number.
By their numbers in this assay, from the lowest: compounds 4, 1, 3 and 2 (each within the scatter of the next).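

In this assay, for the compounds shown here, nitro in place of fluoro on an aromatic carbon, para to a large group, gives a number 4.7 percentage points lower from compound 3 to compound 4 (within the scatter), the first step that can be read at this position. Three heavy atoms and two hydrogen-bond acceptors thus enter in place of a single fluorine with no change in growth inhibition that can be told from the scatter at the one concentration tested. Nothing available bears on why the two groups read alike.

From the compounds shown here alone, it remains open whether an amine or a carboxylic acid at this place would give a step beyond the scatter. A single concentration also leaves open whether compound 3 and compound 4 would still read alike at other concentrations.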